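Replacing the methoxyphenyl in compound 3 with a halogenated ring

The source may hold more compounds than are shown below. What is called first, only, known or untested is meant among the compounds shown, and "the series" means these compounds.

The three measured compounds share one core and differ only in the substituent on the phenyl ring carried by the aromatic nitrogen. Compound 1 `Cn1ccc2c(Oc3ccc(NC(=O)c4cc5cccnc5n(-c5ccc(F)cc5)c4=O)cc3)ccnc21` gives 210 nM in a functional assay on A549 cells (Homo sapiens) for antiproliferative activity, read by MTT assay, with a stated time of 72 h; a higher number here means a weaker inhibitor, a lower number a stronger inhibitor. Compound 2 `Cn1ccc2c(Oc3ccc(NC(=O)c4cc5cccnc5n(-c5ccc(Cl)cc5)c4=O)cc3)ccnc21` gives 630 nM in this assay, and compound 3 `COc1ccc(-n2c(=O)c(C(=O)Nc3ccc(Oc4ccnc5c4ccn5C)cc3)cc3cccnc32)cc1` gives 3460 nM in this assay, the highest of the three numbers. The steps to it are both beyond the scatter: a 16-fold higher number from compound 1 to compound 3 (1.22 log units; beyond the scatter) and a 5.5-fold higher number from compound 2 to compound 3 (0.74 log units; beyond the scatter), while a 3.0-fold higher number from compound 1 to compound 2 (0.48 log units; beyond the scatter).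

Compound 4 `Cn1ccc2c(Oc3ccc(NC(=O)c4cc5cccnc5n(-c5ccc(C(F)(F)F)cc5Cl)c4=O)cc3)ccnc21` is not yet measured. It differs from compound 3 in one place: 2-chloro-4-(trifluoromethyl)phenyl in place of 4-methoxyphenyl on an aromatic nitrogen. The entering ring carries no methoxy and instead bears chloro and trifluoromethyl, so the two steps that bear on it are the ones leading to compound 3 from the fluoro and chloro analogues, both of which show a large or modest rise in the number when methoxy is introduced. Removing the methoxy is therefore expected to move the number back down, with the step from compound 3 to compound 4 expected to be a 4.9-fold lower number from compound 3 to compound 4 (0.69 log units; beyond the scatter). On that basis compound 4 is expected to give about 700 nM in this assay, with a likely range from 200 nM to 2500 nM.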

Compound 4, half-maximal inhibitory concentration: 8250 nM
The estimate for compound 4 lay 12-fold (1.07 log units) below the measured number, and the stated range ends below it.
By their numbers in this assay, from the lowest: compound 1; then compound 2; then compound 3; then compound 4.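

Compound 4 shows that halogen atoms on the ring carried by the aromatic nitrogen do not by themselves give a low number in this assay: the 2-chloro-4-(trifluoromethyl)phenyl ring goes past even the 4-methoxyphenyl ring, with (  a 2.4-fold higher number from compound 3 to compound 4 (0.38 log units; beyond the scatter)  ). The earlier compounds shown here had left the two halogenated rings at the low end, and the new ring separates sharply from both of them, with (  a 13-fold higher number from compound 2 to compound 4 (1.12 log units; beyond the scatter)  ) against the 4-chlorophenyl ring and (  a 39-fold higher number from compound 1 to compound 4 (1.59 log units; beyond the scatter)  ) against the 4-fluorophenyl ring. This position therefore responds to more than the swap of a methoxy for a halogen, and among the four rings shown the 4-fluorophenyl ring remains the one with the lowest number.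

The entering ring brings chloro and trifluoromethyl together. The compounds shown cannot divide the rise between them, and a ring with trifluoromethyl as its only substituent, or one bearing an amine or a carboxylic acid, remains unexplored here. No measurement at hand beyond these antiproliferative numbers speaks to why the number rises.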